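This account rests on a few compounds, and the source may have more. Where it says the series, first, only, none or still open, it means among the compounds named here.

In an in vitro ADME assay on microsomes from liver (Homo sapiens) for metabolic stability (on this read-out higher numbers stand for fast clearance and lower numbers for slow clearance), compound 1 (`CC(C)NC(=O)[C@H]1CC[C@@H](n2/c(=N/C(=O)c3ccc(C#N)c(F)c3)[nH]c3ccc(CN4CCC(C(C)(C)O)CC4)cc32)CC1`) gives 132 mL.min-1.g-1 and stands nearest to compound 3 and furthest from compound 2 among the three numbers available. Compound 3 (`CCNC(=O)[C@H]1CC[C@@H](n2/c(=N/C(=O)c3ccccc3)[nH]c3ccc(CN4CCCCC4)cc32)CC1`) gives 194 mL.min-1.g-1 and lies within the scatter of compound 1, whereas compound 2 (`CC(C)NC(=O)[C@H]1CC[C@@H](n2/c(=N/C(=O)c3ccc(F)cc3)[nH]c3ccc(CN4CCCCC4)cc32)CC1`) gives 302 mL.min-1.g-1 and lies beyond that scatter on the higher side. Neither of these two differs from compound 1 in one place only, so the data offer no direct measure of a single change. Compound 4 (`CC(C)NC(=O)[C@H]1CC[C@@H](n2/c(=N/C(=O)c3ccncc3)[nH]c3ccc(CN4CCC(C(C)(C)O)CC4)cc32)CC1`) keeps everything in compound 1 except one group: pyridin-4-yl in place of 4-cyano-3-fluorophenyl on a carbonyl carbon. The expectation therefore starts from compound 1 at 132 mL.min-1.g-1 and not from the other two compounds, which carry further differences. In this assay a small move toward a lower number is expected, an estimated step (a 1.3-fold lower number from compound 1 to compound 4 (0.12 log units; within the scatter)) that would stay within the scatter. For compound 4 the estimated value is 100 mL.min-1.g-1 with a range from 55 mL.min-1.g-1 to 180 mL.min-1.g-1 as the expected span of the measurement.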

Compound 4, intrinsic clearance in microsomes: 57 mL.min-1.g-1
Compound 4: middle estimate off by 1.8-fold (0.24 log units), on the high side, and the stated range covers the measured number.
By their numbers in this assay, from the lowest: compound 4; then compounds 1, 3 and 2 (each within the scatter of the next, the first and the last beyond it).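

In this assay, replacing the 4-cyano-3-fluorophenyl on a carbonyl carbon with pyridin-4-yl gives a 2.3-fold lower number from compound 1 to compound 4 (0.36 log units; beyond the scatter), with everything else in the structure of compound 1 left unchanged. Among these compounds, this is the first direct sign that this position alone can move microsomal clearance beyond the usual scatter, which compound 2 and compound 3 could not show, as each differs from compound 1 in more than one place. The data show only the size and direction of this step, and no measurement at hand accounts for it.

Among the compounds shown here, the single step changes several things at once: the nitrile and the fluorine both leave, and a ring nitrogen enters, so it cannot be divided among them. Going by these compounds, it also remains open where a 4-cyanophenyl, a 3-fluorophenyl, a pyridin-3-yl or a pyrimidin-5-yl on the same carbonyl carbon would fall relative to compound 1 and compound 4, and whether the same exchange would give a similar step with a different amide or amine elsewhere in the molecule.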